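Exchanging the pyrazole of compound 3 for a pyridine

A few compounds are considered here, and "the series" means these few. Any claim that something is new, unique, unknown or untested is made for them only; others in the source may bear on it.

The three measured compounds share the core of compound 2 `c1ccc2c(c1)CCC2c1ncc[nH]1` and differ only in the group carried on an aromatic carbon of its fused ring. In a functional assay on CHO cells for agonist activity at Alpha-1A adrenergic receptor (Homo sapiens), read by FLIPR and calcium flux (on this read-out higher numbers stand for an effect only at larger amounts of compound and lower numbers for an effect already at smaller amounts), compound 2 gives 473 nM. Compound 1 `c1ccc(-c2cccc3c2CCC3c2ncc[nH]2)nc1` bears a pyridin-2-yl there and gives 1150 nM. Compound 3 `c1cc(-c2ccn[nH]2)c2c(c1)C(c1ncc[nH]1)CC2` bears a 1H-pyrazol-5-yl and gives 52 nM; it stands lowest of the three numbers, with a 9.1-fold lower number from compound 2 to compound 3 (0.96 log units; beyond the scatter) and a 22-fold lower number from compound 1 to compound 3 (1.34 log units; beyond the scatter).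

Compound 4 `c1cncc(-c2cccc3c2CCC3c2ncc[nH]2)c1` is the next variant: pyridin-3-yl in place of 1H-pyrazol-5-yl on an aromatic carbon. The step that bears most directly on this change is a 22-fold lower number from compound 1 to compound 3 (1.34 log units; beyond the scatter), since both groups that leave there and enter here are six-membered pyridines without a donor, and a 2.4-fold lower number from compound 1 to compound 2 (0.39 log units; beyond the scatter) shows that the earlier pyridine did not even match the bare core. He therefore expects compound 4 to lose most of the ground gained by compound 3, with a rise of about a 13-fold higher number from compound 3 to compound 4 (1.13 log units; beyond the scatter) in this assay. His estimate for compound 4 is 700 nM, within a range of 200 nM to 2500 nM.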

Compound 4, half-maximal effective concentration: 2060 nM
The estimate for compound 4 lay 2.9-fold (0.47 log units) below the measured number; the measured number falls inside the stated range.
By their numbers in this assay, from the lowest: compound 3; then compound 2; then compounds 1 and 4 (each within the scatter of the next).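

In this assay, pyridin-3-yl gives up all that the 1H-pyrazol-5-yl had gained, with a 40-fold higher number from compound 3 to compound 4 (1.60 log units; beyond the scatter), and it does not even hold the level of the unsubstituted core, with a 4.4-fold higher number from compound 2 to compound 4 (0.64 log units; beyond the scatter). Exchanging one pyridine for the other makes no clear difference, with a 1.8-fold higher number from compound 1 to compound 4 (0.25 log units; within the scatter), so both pyridinyl groups shown lie on the high side of hydrogen at this aromatic carbon, and the 1H-pyrazol-5-yl alone lies on the low side. No measurement at hand accounts for the gap between the 1H-pyrazol-5-yl and the pyridines.

The exchange changes ring size and hydrogen-bond donor count together, so the compounds shown cannot separate the two. They also leave open how a plain phenyl, a furan or an imidazole ring would fare at this place.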